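Spiro amide series: chain amide replaces ester piperidine

A few compounds are considered here, and "the series" means these few. Any claim that something is new, unique, unknown or untested is made for them only; others in the source may bear on it.

Measured compounds:
compound 1 `CC(C)(C)c1ccc(C(=O)N2CCC3(CC2)C(=O)N(CC(=O)N2CCCC(C(N)=O)C2)CN3c2ccccc2)cc1` 16900 nM
compound 2 `CC(C)(C)c1ccc(C(=O)N2CCC3(CC2)C(=O)N(CC(=O)NCCCCO)CN3c2ccccc2)cc1` 19200 nM
compound 3 `CCOC(=O)C1CCCN(C(=O)CN2CN(c3ccccc3)C3(CCN(C(=O)c4ccc(C(C)(C)C)cc4)CC3)C2=O)C1` 8200 nM

In an assay on HEK293 cells for displacement of a labelled ligand from NPC1-like intracellular cholesterol transporter 1 (Homo sapiens) (a higher number here means a weaker inhibitor, a lower number a stronger inhibitor), compound 3 gives the lowest of the three numbers: a 2.1-fold lower number from compound 1 to compound 3 (0.31 log units; beyond the scatter) and a 2.3-fold lower number from compound 2 to compound 3 (0.37 log units; beyond the scatter), both beyond the scatter but modest. Compound 1 and compound 2 sit within the scatter of each other, a 1.1-fold higher number from compound 1 to compound 2 (0.06 log units; within the scatter).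

Compound 4 `CC(C)(C)c1ccc(C(=O)N2CCC3(CC2)C(=O)N(CC(=O)NCCCCNS(C)(=O)=O)CN3c2ccccc2)cc1` is not yet measured. It differs from compound 3 in one place: (4-(methanesulfonamido)butyl)amino in place of 3-(ethoxycarbonyl)piperidin-1-yl on a carbonyl carbon

Among the measured compounds shown here, the step that bears on it most is the one from compound 2, the other open-chain amide, to compound 3: a 2.3-fold lower number from compound 2 to compound 3 (0.37 log units; beyond the scatter). Compound 4 reverses that change in kind, returning to a chain amide of the sort seen in compound 2, though with a different terminal group. The step of a 2.1-fold lower number from compound 1 to compound 3 (0.31 log units; beyond the scatter) likewise shows the ethoxy-bearing compound giving the lower number. A modest rise back toward the values of compound 1 and compound 2 is therefore expected, a 2.1-fold higher number from compound 3 to compound 4 (0.32 log units; beyond the scatter). Compound 4 is estimated at 17000 nM, with a range of 8000 nM to 36000 nM.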

Compound 4, half-maximal inhibitory concentration: 4500 nM
Compound 4: the middle estimate sits 3.8-fold (0.58 log units) above what was measured; measured number below the stated range.
By their numbers in this assay, from the lowest: compounds 4 and 3 (each within the scatter of the next); then compounds 1 and 2 (each within the scatter of the next).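

In this assay the terminal group on the chain amide carries weight: a 4.3-fold lower number from compound 2 to compound 4 (0.63 log units; beyond the scatter) with methanesulfonamido in place of hydroxy on a saturated chain carbon, so the open chain as such does not fix the number at the level of compound 2. The chain with this terminal group also separates from the carbamoyl piperidine, a 3.8-fold lower number from compound 1 to compound 4 (0.57 log units; beyond the scatter) and yet stays level with the ester piperidine, a 1.8-fold lower number from compound 3 to compound 4 (0.26 log units; within the scatter) within the scatter, which removes the earlier impression that only the ester piperidine gave the lower number. Nothing measured here accounts for the effect of the terminal group.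

Going by these compounds, whether the step belongs to methanesulfonamido specifically stays open: an acetamido group, an amine or a carboxylic acid at the end of the same chain would test this. A shorter or longer chain carrying methanesulfonamido would show how much the chain length contributes.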